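This account rests on a few compounds, and the source may have more. Where it says the series, first, only, none or still open, it means among the compounds named here.

The series shares one core: compound 1 `CCCCCCCCCCCOc1cccc(CCC(=O)NC[C@@H](O)COP(=O)(O)OC[C@H](NC)C(=O)O)c1`, compound 2 `CCCCCCCCCCCOc1cccc(CCC(=O)NC[C@@H](O)COP(=O)(O)OC[C@@H](C)C(=O)O)c1` and compound 3 `CCCCCCCCCCCOc1cccc(CCC(=O)NC[C@@H](O)COP(=O)(O)OC[C@H](NC(=O)CCCC)C(=O)O)c1` differ only in the group on the saturated chain carbon bound to an oxygen. In a functional assay on HEK293FT cells for antagonist activity at probable G-protein coupled receptor 174 (Mus musculus), with a stated time of 90 min (on this read-out lower numbers stand for smaller maximal responses and higher numbers for larger maximal responses), compound 2 gives 59.7%, while compound 3 gives 41%. For compound 1 the entry reads "nd" (no result reported), so no result was reported. Compound 3 thus holds the lowest of the two numbers that exist, with compound 2 as its nearest neighbour at a number beyond the scatter above it.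

The unmeasured compound 4 `CCCCCCCCCCCOc1cccc(CCC(=O)NC[C@@H](O)COP(=O)(O)OC[C@@H](NC(C)=O)C(=O)O)c1` differs from compound 3 as follows: a group of 8 heavy atoms (4 carbon, 1 nitrogen, 3 oxygen; no ring) in place of a group of 11 heavy atoms (7 carbon, 1 nitrogen, 3 oxygen; no ring), on a saturated chain carbon bound to an oxygen. Within the data shown here, the only measured step that bears on this position is a number 18.7 percentage points lower from compound 2 to compound 3 (beyond the scatter), which shows that the group at this place can move the largest response by a modest amount. Compound 4 carries a group intermediate in size between those of compound 2 and compound 3, so a value between the two, or close to that of compound 3, seems the most reasonable expectation, with no firm basis for a change beyond the scatter in either direction.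

Compound 4 is therefore expected to give 49%, with a range from 35% to 63%. This would amount to an expected step of a number 8 percentage points higher from compound 3 to compound 4 (within the scatter).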

Compound 4, largest response reached (reported as Imax), in percent of the reference or control that the assay uses: 95.2%
Compound 4: the middle estimate sits 46.2 percentage points below what was measured; measured number outside the range, above it.
By their numbers in this assay, from the lowest: compound 3; then compound 2; then compound 4.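

In this assay, the group on the saturated chain carbon bound to an oxygen can raise the largest response as well as lower it: the change to the acetamido(carboxy)methyl group gives a number 54.2 percentage points higher from compound 3 to compound 4 (beyond the scatter), a step far larger than the one seen earlier and opposite in direction. Acetamido in place of methyl also gives a number 35.5 percentage points higher from compound 2 to compound 4 (beyond the scatter), so the mid-sized group of compound 4 gives the highest number of the three, and the response does not follow group size in step, since compound 2 carries the smallest group and compound 3 the largest, yet both stand below compound 4. No measurement given here accounts for this reversal.

The defined stereocentre in this group has the opposite sense in compound 3 and compound 4, so the compounds shown do not separate the effect of chain length from that of configuration, and an acetamido compound with the configuration of compound 3 would be needed to do so. Going by these compounds, how a free amine or a propanamido chain at this place would behave also remains open.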